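Placing 1H-pyrazol-1-yl on the chain of compound 3

A few compounds are considered here, and "the series" means these few. Any claim that something is new, unique, unknown or untested is made for them only; others in the source may bear on it.

In a functional assay on HUVEC cells (Homo sapiens), read by scintillation counting and thymidine incorporation, with a stated time of 24 h (on this read-out higher numbers stand for weaker inhibition and lower numbers for stronger inhibition), compound 3 `CCC(C)n1ncn(-c2ccc(N3CCN(c4ccc(OC[C@@H]5CO[C@@](Cn6cc(C(F)(F)F)nc6C)(c6ccc(Cl)cc6Cl)O5)cc4)CC3)cc2)c1=O` gives 441 nM, within the scatter of compound 2 `CCC(C)n1ncn(-c2ccc(N3CCN(c4ccc(OC[C@@H]5CO[C@@](Cn6cc(C)nc6C)(c6ccc(Cl)cc6Cl)O5)cc4)CC3)cc2)c1=O` at 492 nM, while compound 1 `CCC(C)n1ncn(-c2ccc(N3CCN(c4ccc(OC[C@@H]5CO[C@@](Cn6ccnc6C(C)C)(c6ccc(Cl)cc6Cl)O5)cc4)CC3)cc2)c1=O` gives the lowest number, 84 nM. Compound 4 `CCC(C)n1ncn(-c2ccc(N3CCN(c4ccc(OC[C@@H]5CO[C@@](Cn6cccn6)(c6ccc(Cl)cc6Cl)O5)cc4)CC3)cc2)c1=O` differs from compound 3 at one place: 1H-pyrazol-1-yl in place of 2-methyl-4-(trifluoromethyl)-1H-imidazol-1-yl on a saturated chain carbon bound to a saturated ring carbon. The new group, 1H-pyrazol-1-yl, sits on a saturated chain carbon bound to a saturated ring carbon. Three measured steps changed groups at this place. The exchanges a 5.9-fold higher number from compound 1 to compound 2 (0.77 log units; beyond the scatter) and a 5.3-fold higher number from compound 1 to compound 3 (0.72 log units; beyond the scatter) were modest, whereas a 1.1-fold lower number from compound 2 to compound 3 (0.05 log units; within the scatter) stayed within the scatter. Among the compounds with values here, no measured compound carries 1H-pyrazol-1-yl, so no firm direction can be drawn, and no step beyond the scatter is expected. The expected step is a 1.1-fold higher number from compound 3 to compound 4 (0.05 log units; within the scatter). For compound 4 the estimated value is 500 nM, with an expected range of 150 nM to 1700 nM.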

Compound 4, half-maximal inhibitory concentration: 307 nM
Estimate against measurement, compound 4: 1.6-fold (0.21 log units) above; the measured number falls inside the stated range.
By their numbers in this assay, from the lowest: compound 1; then compounds 4, 3 and 2 (each within the scatter of the next).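

In this assay, replacing either substituted imidazole with the smaller, unsubstituted 1H-pyrazol-1-yl changes little: a 1.4-fold lower number from compound 3 to compound 4 (0.16 log units; within the scatter) and a 1.6-fold lower number from compound 2 to compound 4 (0.20 log units; within the scatter) both stay within the scatter. Only the 2-isopropyl-1H-imidazol-1-yl of compound 1 stands apart among these four, with a 3.7-fold higher number from compound 1 to compound 4 (0.56 log units; beyond the scatter) lying beyond the scatter. No supporting data here bear on the reason for these steps.

Still open, going by these compounds, is whether an isopropyl group on the 1H-pyrazol-1-yl ring would bring the number close to that of compound 1. On these data alone, how an amine or a carboxylic acid would behave at this chain carbon also remains open.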